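The source may report more compounds than this note shows. Statements on the series, on what has been measured and on what is new or still open speak of the compounds shown alone.

Going by the values given here, in a functional assay on HT-29 cells (Homo sapiens) for antiproliferative activity (on this read-out higher numbers stand for weaker inhibition and lower numbers for stronger inhibition), compound 1 `COc1ccc(S(=O)(=O)N2CCc3cccc(Nc4ccc(Cl)cc4)c32)cc1` gives 658 nM and compound 2 `COc1ccc(S(=O)(=O)N2CCc3cccc(Nc4ccc(F)cc4)c32)cc1` gives 588 nM here, so compound 2 stands level with the only other number measured. Compound 3 `COc1ccc(S(=O)(=O)N2CCc3cccc(Nc4ccc([N+](=O)[O-])cc4)c32)cc1` carries nitro in place of fluoro on an aromatic carbon, para to a large group, a change counted as nitro in place of fluoro on an aromatic carbon in full. Among the compounds with values here, the one measured step at this place is a 1.1-fold lower number from compound 1 to compound 2 (0.05 log units; within the scatter) and covers only chloro and fluoro, so the data bound nitro poorly. In this assay no step beyond the scatter is expected, in either direction, and the estimated step is a 1.2-fold higher number from compound 2 to compound 3 (0.08 log units; within the scatter) for now. For compound 3 the expected value is 700 nM with a range of 200 nM to 2500 nM as its estimate.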

Compound 3, half-maximal inhibitory concentration: 191 nM
Beside the measured number, compound 3's estimate is 3.7-fold (0.56 log units) above it; the whole stated range lies above it.
By their numbers in this assay, from the lowest: compound 3; then compounds 2 and 1 (each within the scatter of the next).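

In this assay the aromatic carbon para to a large group turns out to respond to what it carries: nitro in place of fluoro gives a 3.1-fold lower number from compound 2 to compound 3 (0.49 log units; beyond the scatter) and nitro in place of chloro gives a 3.4-fold lower number from compound 1 to compound 3 (0.54 log units; beyond the scatter) while the two halogens had stayed within the scatter of each other. The position is therefore not indifferent to its substituent, although both steps are modest. Nothing available here accounts for the change.

Still open, as far as these compounds go, is whether an amine, a nitrile or a carboxylic acid at this place would follow nitro or stay with the halogens.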